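A few compounds are considered here, and "the series" means these few. Any claim that something is new, unique, unknown or untested is made for them only; others in the source may bear on it.

For the measured compounds named here, in an ADME assay on J774.A1 cells (Mus musculus) for cytotoxicity, read by MTT assay, with a stated time of 48 h (a higher number here means that more compound is tolerated, a lower number that less compound is tolerated), compound 2 (`COC(=O)c1c([N+](=O)[O-])noc1-c1ccc(Cl)cc1Cl`) gives 19700 nM and this is the only number available, so it cannot be placed high or low against any other compound. Its companion, compound 1 (`COC(=O)c1c([N+](=O)[O-])noc1-c1ccc(Cl)cc1`), has the entry "not determined" (no result reported) and offers no comparison. The next compound to be measured, compound 3 (`COC(=O)c1c(NCc2ccccc2)noc1-c1ccc(Cl)cc1Cl`), carries benzylamino in place of nitro on an aromatic carbon while the rest of compound 2 stays unchanged. Going by the values given here, no measured pair shows what this replacement does in this assay and the expectation therefore remains loose. The step expected is small and toward more compound tolerated, estimated as a 1.5-fold higher number from compound 2 to compound 3 (0.18 log units; within the scatter) and within the usual scatter. For compound 3 the estimated half-maximal cytotoxic concentration is 30000 nM with an expected range from 10000 nM to 90000 nM in this test.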

Compound 3, half-maximal cytotoxic concentration: 54200 nM
For compound 3 the middle estimate is 1.8-fold (0.26 log units) below the measured one; low and high end bracket the measured number.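

For the compounds shown here, the replacement of nitro by benzylamino on an aromatic carbon next to the ring nitrogen gives a 2.8-fold higher number from compound 2 to compound 3 (0.44 log units; beyond the scatter) in this assay, the first sign that a change at this position can move this read-out. Going by these compounds alone, the pair also shows that a much larger group with a six-membered aromatic ring of carbon only and a hydrogen-bond donor can enter here without lowering the number, although the single step cannot separate these features from the loss of nitro. No measured evidence accompanies this step, so it stands without an explanation.

The compounds shown leave open whether a plain amino group or methylamino would give a similar step, which would indicate whether the nitrogen or the benzyl part matters. They also leave open whether a longer chain, such as phenethylamino, would carry the trend further.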